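The source may hold more compounds than are shown below. What is called first, only, known or untested is meant among the compounds shown, and "the series" means these compounds.

Compound 1 `COc1cc(-c2nc3ccccc3s2)ccc1OCC(=O)NNC(=O)CN(C(C)=O)[C@@H](CS)C(=O)O` gives 1750 nM
Compound 2 `CCOC(=O)[C@H](NCC(=O)NNC(=O)COc1ccc(-c2nc3ccccc3s2)cc1OC)[C@@H](C)CC` gives 2900 nM

For the measured compounds named here, in a functional assay on MCF7 cells (Homo sapiens) for inhibition, read by MTT assay, with a stated time of 3 days (a higher number here means a weaker inhibitor, a lower number a stronger inhibitor), compound 2 at 2900 nM stands within the usual scatter of compound 1, the only other measured compound. Compound 3 `CCOC(=O)[C@@H]1CCCN1CC(=O)NNC(=O)COc1ccc(-c2nc3ccccc3s2)cc1OC` has not yet been measured. Its difference from compound 2 2-(ethoxycarbonyl)pyrrolidin-1-yl in place of (1-(ethoxycarbonyl)-2-methylbutyl)amino on a saturated chain carbon bound to a carbonyl carbon puts 2-(ethoxycarbonyl)pyrrolidin-1-yl in place of (1-(ethoxycarbonyl)-2-methylbutyl)amino on a saturated chain carbon bound to a carbonyl carbon. Going by the values given here, the only measured step at that place a 1.7-fold higher number from compound 1 to compound 2 (0.22 log units; within the scatter) stays within the scatter, so no step beyond the scatter is expected in this assay here. The expected change is an estimated 1.2-fold lower number from compound 2 to compound 3 (0.06 log units; within the scatter) and nothing larger. The estimated value for compound 3 is 2500 nM with an expected range from 900 nM to 7000 nM for this measurement.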

Compound 3, half-maximal inhibitory concentration: 770 nM
Beside the measured number, compound 3's estimate is 3.2-fold (0.51 log units) above it, and the stated range ends above it.
By their numbers in this assay, from the lowest: compound 3; then compounds 1 and 2 (each within the scatter of the next).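

In this assay, the place on a saturated chain carbon bound to a carbonyl carbon now shows a change beyond the scatter, which the earlier pair did not. 2-(ethoxycarbonyl)pyrrolidin-1-yl in place of (1-(ethoxycarbonyl)-2-methylbutyl)amino gives a 3.8-fold lower number from compound 2 to compound 3 (0.58 log units; beyond the scatter) and in place of acetyl(1-carboxy-2-sulfanylethyl)amino gives a 2.3-fold lower number from compound 1 to compound 3 (0.36 log units; beyond the scatter), making compound 3 the strongest of the three. Nothing measured here bears on the cause of these steps.

Still open, going by these compounds, is whether the five-membered ring itself matters. A six-membered piperidine ring, or a carboxylic acid in place of the ethyl ester on the pyrrolidine, would test this in this assay.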